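The source may report more compounds than this note shows. Statements on the series, on what has been measured and on what is new or still open speak of the compounds shown alone.

Compound 1: `Cc1c(C)c2c(c(C)c1O)CCC(C)(C(=O)N1CCCC1)O2`, 10000 nM
Compound 2: `Cc1c(C)c2c(c(C)c1O)CCC(C)(CN1CCNCC1)O2`, 1000 nM

Within the data shown here, in a functional assay (brain) for inhibition, with Rattus norvegicus as the target (a higher number here means a weaker inhibitor, a lower number a stronger inhibitor), compound 2 holds the lowest of the two numbers; its only neighbour is compound 1, and the step of a 10-fold lower number from compound 1 to compound 2 (1.00 log units; beyond the scatter) lies beyond the scatter. That step put (piperazin-1-yl)methyl in place of (pyrrolidin-1-yl)carbonyl, so it mixed two alterations at once and bears only loosely on compound 3, `Cc1c(C)c2c(c(C)c1O)CCC(C)(CN1CCCC1)O2`, which differs from compound 2 in a single respect: pyrrolidin-1-yl in place of piperazin-1-yl on a saturated chain carbon bound to a saturated ring carbon. Among the measured compounds shown here, no measured pair shows this change on its own. The earlier step ran partly in the opposite direction of the ring, so a modest rise in the number, or no change beyond the scatter, is expected for compound 3. Compound 3 is therefore estimated at 2000 nM, within a range of 600 nM to 8000 nM, a step of a 2.0-fold higher number from compound 2 to compound 3 (0.30 log units; within the scatter) that is expected to be small.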

Compound 3, half-maximal inhibitory concentration: 1400 nM
Beside the measured number, compound 3's estimate is 1.4-fold (0.15 log units) above it; measured number inside the range.
By their numbers in this assay, from the lowest: compounds 2 and 3 (each within the scatter of the next); then compound 1.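

In this assay, a 1.4-fold higher number from compound 2 to compound 3 (0.15 log units; within the scatter) shows that on a saturated chain carbon bound to a saturated ring carbon, pyrrolidin-1-yl can stand in for piperazin-1-yl, even with one nitrogen and the hydrogen-bond donor gone, without a change that can be told from the scatter. The a 7.1-fold lower number from compound 1 to compound 3 (0.85 log units; beyond the scatter) isolates what the earlier step had mixed: with the pyrrolidine ring kept, (pyrrolidin-1-yl)methyl in place of (pyrrolidin-1-yl)carbonyl on its own gives a step beyond the scatter. No independent measurement is available to explain either result. Still open, as far as these compounds go, is whether morpholin-4-yl or an open-chain amine such as dimethylamino on the same carbon would stay within the scatter of compound 3. Also open, from the compounds shown here alone, is how a longer chain in place of the methyl link would affect the number.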